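The compounds below may be only part of what the source reports. "The series", "measured", "known", "first", "only" and "open" are said of these compounds alone.

Values in a functional assay on HeLa cells (Homo sapiens) for antiproliferative activity, with a stated time of 24 h; a higher number here means a weaker inhibitor, a lower number a stronger inhibitor:
- compound 1 `NC(=O)c1c(NC(=O)c2ccccc2Cl)sc2c1CCN(Cc1ccc(Cl)cc1)C2`: > 50000 nM
- compound 2 `NC(=O)c1c(NC(=O)c2ccccc2Cl)sc2c1CCN(Cc1ccc([N+](=O)[O-])cc1)C2`: 46100 nM
- compound 3 `NC(=O)c1c(NC(=O)c2ccccc2Cl)sc2c1CCN(Cc1c(Cl)cccc1Cl)C2`: 28800 nM

Compound 1 gives > 50000 nM, which is a limit of the assay and not a number. For the measured compounds named here, that leaves compound 2 and compound 3 as the only two numbers, and they sit within the scatter of each other: a 1.6-fold lower number from compound 2 to compound 3 (0.20 log units; within the scatter). Compound 3 therefore has no real separation from its nearest neighbour. The steps that start from compound 1 give only floors: an at least 1.0-fold lower number from compound 1 to compound 2 (0.03 log units; that floor lies within the scatter), and an at least 1.7-fold lower number from compound 1 to compound 3 (0.23 log units; that floor lies within the scatter).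

Compound 4 `NC(=O)c1c(NC(=O)c2ccccc2F)sc2c1CCN(Cc1c(Cl)cccc1Cl)C2` differs from compound 3 at the other aryl group, 2-chlorophenyl to 2-fluorophenyl: fluoro in place of chloro on an aromatic carbon. The change is fluoro in place of chloro on an aromatic carbon, ortho to a large group.

Going by the values given here, none of the measured steps touches this group. They exchange only 4-chlorophenyl, 4-nitrophenyl and 2,6-dichlorophenyl, so they offer no direct size for this change. All that they show is a series with no step beyond the scatter. No step beyond the scatter is therefore expected in this assay, and no direction can be favoured. The expected step is a 1.0-fold higher number from compound 3 to compound 4 (0.02 log units; within the scatter). For compound 4 the estimated value is 30000 nM, with an expected range of 13000 nM to 50000 nM.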

Compound 4, half-maximal inhibitory concentration: 33000 nM
For compound 4 the middle estimate is 1.1-fold (0.04 log units) below the measured one; low and high end bracket the measured number.
By their numbers in this assay, from the lowest: compounds 3, 4 and 2 (each within the scatter of the next). At a limit, above all of these: compound 1.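

In this assay, for the compounds shown here, the exchange at the 2-chlorophenyl group reads a 1.1-fold higher number from compound 3 to compound 4 (0.06 log units; within the scatter), and this is the first measured step at this aryl group, since the earlier steps exchange only the groups on the saturated chain carbon. At this place, on an aromatic carbon ortho to a large group, fluoro and chloro therefore cannot be told apart in this assay, and compound 3 and compound 4 carry no order between them. Compound 1 stands at a limit of the assay and not at a number, so one member of the series gives no size for any step: the limit of > 50000 nM in this assay, at which 1 of the 4 values shown sits.

It remains open whether this aromatic carbon responds to anything other than a halogen, as the compounds shown hold only chloro and fluoro there and say nothing about an amine, a methoxy group or a carboxylic acid in that place. As far as these compounds go, it also remains open whether any single change can produce a step beyond the scatter in this assay, and a longer chain on the amine nitrogen in the ring is one untested way to probe the other end of the molecule.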